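Sugar to dihydroxypropyl on the shared core

The compounds below may be only part of what the source reports. "The series", "measured", "known", "first", "only" and "open" are said of these compounds alone.

Values in a functional assay on A-375 cells (Homo sapiens) for cytotoxicity, read by MTT assay, with a stated time of 72 h; a lower number here means a stronger inhibitor, a higher number a weaker inhibitor:
- compound 1 `CC1(C)OC[C@@H](Cn2cc(Cn3c4c(c5ccccc53)C(=O)c3c[n+]([O-])c5ccccc5c3C4=O)nn2)O1`: 450 nM
- compound 2 `O=C1c2c[n+]([O-])c3ccccc3c2C(=O)c2c1c1ccccc1n2Cc1cn([C@@H]2O[C@H](CO)[C@@H](O)[C@H](O)[C@H]2O)nn1`: 230 nM

Compound 2 stands at 230 nM with only compound 1 for comparison, and the two values lie within the scatter of each other, so neither ranks ahead.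

Compound 3 `O=C1c2c[n+]([O-])c3ccccc3c2C(=O)c2c1c1ccccc1n2Cc1cn(C[C@@H](O)CO)nn1` keeps the shared core and changes one place: 2,3-dihydroxypropyl in place of 3,4,5-trihydroxy-6-(hydroxymethyl)oxan-2-yl on an aromatic nitrogen. In words, this puts 2,3-dihydroxypropyl in place of 3,4,5-trihydroxy-6-(hydroxymethyl)oxan-2-yl on an aromatic nitrogen.

Going by the values given here, one measured step bears on this, at the same nitrogen: a 2.0-fold lower number from compound 1 to compound 2 (0.29 log units; within the scatter). It brought in the group now being removed, and it did not move the number beyond the scatter. Two quite different groups at this place thus gave values that cannot be separated, though two compounds are a thin basis and the 2,3-dihydroxypropyl group itself has not been measured.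

In this assay, no shift beyond the scatter is therefore expected, and the estimated change is a 1.3-fold higher number from compound 2 to compound 3 (0.12 log units; within the scatter).

The expected value for compound 3 is 300 nM, with an estimated range of 120 nM to 750 nM.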

Compound 3, half-maximal inhibitory concentration: 140 nM
Beside the measured number, compound 3's estimate is 2.1-fold (0.33 log units) above it; the range from low to high includes it.
By their numbers in this assay, from the lowest: compounds 3, 2 and 1 (each within the scatter of the next, the first and the last beyond it).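

In this assay, 1,2-dihydroxyethyl in place of 2,2-dimethyl-1,3-dioxolan-4-yl on the saturated chain carbon bound to the aromatic nitrogen gives the first separation in this series (a 3.2-fold lower number from compound 1 to compound 3 (0.51 log units; beyond the scatter)), a modest step and the only one of the three that clears the scatter. At the aromatic nitrogen itself, 2,3-dihydroxypropyl in place of 3,4,5-trihydroxy-6-(hydroxymethyl)oxan-2-yl gives no such separation (a 1.6-fold lower number from compound 2 to compound 3 (0.22 log units; within the scatter)), so the six-membered non-aromatic ring and most of the defined stereocentres can leave this position without a shift beyond the scatter. No supporting measurement bears on why either step falls as it does.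

The compounds shown leave open whether the free hydroxyl groups of the 2,3-dihydroxypropyl chain carry the separation from compound 1, which a plain propyl chain, a 2-aminoethyl chain or a carboxylic acid on the same nitrogen would test. Also open, on these data alone, is whether the single defined stereocentre of the 2,3-dihydroxypropyl group matters, which the opposite configuration of that chain would address.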